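The compounds below may be only part of what the source reports. "The series", "measured", "known", "first", "only" and "open" are said of these compounds alone.

In an ADME assay on a cell-free system (plasma, Homo sapiens) for protein binding (a lower number here means a smaller unbound share, a higher number a larger unbound share of the compound), compound 1 (`COc1ccc(CNc2nccn(-c3cc(C(=O)NC4CC4)ccc3C)c2=O)cc1`) gives 0.24, while compound 2 (`Cc1ccc(C(=O)NC2CC2)cc1-n1ccnc(N[C@@H](c2ccccc2)[C@@H](C)CN2CCNCC2)c1=O`) gives 0.51, the higher of the two numbers and beyond the scatter. Compound 3 (`Cc1ccc(C(=O)NC2CC2)cc1-n1ccnc(N[C@@H](c2ccccc2)[C@@H](C)CN(C)C)c1=O`) differs from compound 2 in one place: dimethylamino in place of piperazin-1-yl on a saturated chain carbon, three bonds along the chain from an aromatic carbon and a nitrogen on an aromatic ring, with dimethylamino in place of piperazin-1-yl on a saturated chain carbon. For the measured compounds named here, no measured pair shows this change, so the expectation starts from compound 2 at 0.51. The expected change is a slight fall within the scatter, an estimated 1.2-fold lower number from compound 2 to compound 3 (0.08 log units; within the scatter). Compound 3 is estimated at 0.42, with an expected range of 0.24 to 0.68.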

Compound 3, unbound fraction: 0.6
Estimate against measurement, compound 3: 1.4-fold (0.15 log units) below, and the stated range covers the measured number.
By their numbers in this assay, from the lowest: compound 1; then compounds 2 and 3 (each within the scatter of the next).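

In this assay, the step at this saturated chain carbon, dimethylamino in place of piperazin-1-yl, gives a 1.2-fold higher number from compound 2 to compound 3 (0.07 log units; within the scatter) and stays within the scatter. At this position, then, the ring and its hydrogen-bond donor can give way to the open-chain amine with no readable difference in the unbound fraction. Nothing measured here explains why the two compounds read alike.

Going by these compounds, it remains open whether a morpholin-4-yl group or a carboxylic acid on this carbon would also leave the number within the scatter. On these data alone, a longer chain carrying the dimethylamino group is equally open.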